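The source may report more compounds than this note shows. Statements on the series, on what has been measured and on what is new or still open speak of the compounds shown alone.

Measured so far in a functional assay (trachea) with Cavia porcellus as the target (on this read-out lower numbers stand for an effect already at smaller amounts and higher numbers for an effect only at larger amounts of compound), are three compounds
Compound 1 `C=CCCn1c(=O)c2[nH]cnc2n(CCC)c1=O` gives 200 nM
Compound 2 `CCCn1c(=O)n(CCN(C)C)c(=O)c2[nH]cnc21` gives 2700 nM
Compound 3 `CCCn1c(=O)n(CCO)c(=O)c2[nH]cnc21` gives 510 nM

Compound 3 holds the middle place among these numbers. The gap to its nearest neighbour is a 2.6-fold higher number from compound 1 to compound 3 (0.41 log units; beyond the scatter) and the gap to its furthest is a 5.3-fold lower number from compound 2 to compound 3 (0.72 log units; beyond the scatter) on the same scale.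

The next compound is compound 4 `CCCn1c(=O)n(CCCO)c(=O)c2[nH]cnc21` and the change is hydroxymethyl in place of hydroxy on a saturated chain carbon, two bonds along the chain from an aromatic nitrogen with hydroxymethyl in place of hydroxy on a saturated chain carbon, two bonds along the chain from an aromatic nitrogen. This turns 2-hydroxyethyl into 3-hydroxypropyl.

For the measured compounds named here, no measured step makes this exact change, but three were made at the same place. The largest is a 14-fold higher number from compound 1 to compound 2 (1.13 log units; beyond the scatter) and it involves dimethylamino, which plays no part here. Compound 4 keeps its hydroxy, so the modest step of a 2.6-fold higher number from compound 1 to compound 3 (0.41 log units; beyond the scatter) is the better guide to scale. No step beyond the scatter is therefore expected, with a slight lean towards a lower number. The expected step is a 1.4-fold lower number from compound 3 to compound 4 (0.15 log units; within the scatter) and it remains only an estimate. The estimated value for compound 4 is 360 nM with an expected range from 150 nM to 900 nM until the measurement arrives.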

Compound 4, half-maximal effective concentration: 5100 nM
Compound 4: the middle estimate sits 14-fold (1.15 log units) below what was measured; measured number above the stated range.
By their numbers in this assay, from the lowest: compound 1; then compound 3; then compounds 2 and 4 (each within the scatter of the next).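

In this assay, turning 2-hydroxyethyl into 3-hydroxypropyl gives a 10-fold higher number from compound 3 to compound 4 (1.00 log units; beyond the scatter), so at this position the length of the chain counts, and not only the kind of group at its end. Keeping the hydroxy is therefore not enough to hold the number low: the step from the vinyl-bearing chain is a 26-fold higher number from compound 1 to compound 4 (1.41 log units; beyond the scatter), far larger than the step from the same compound to the shorter hydroxy chain. Compound 4 also ends up level with the dimethylamino compound, with a 1.9-fold higher number from compound 2 to compound 4 (0.28 log units; within the scatter), so two quite different end groups give matching numbers here.

Nothing available explains why one added carbon has such an effect. Going by these compounds, whether a longer hydroxy-ended chain, or a carboxylic acid on the chain, would read like compound 3 or like compound 4 remains open.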